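Removing Piperidine from an Amide: A Lipophilicity Estimate

A few compounds are considered here, and "the series" means these few. Any claim that something is new, unique, unknown or untested is made for them only; others in the source may bear on it.

Measured so far in a physicochemical assay for lipophilicity, using the shake flask method, measured as octanol-water partition, at pH 7.4 (a lower number here means a more polar compound, a higher number a more lipophilic compound), are two compounds:
- compound 1 `COc1cc(F)ccc1-c1ccnc2[nH]c(C3CCN(CC(=O)N(C)C)CC3)cc12` gives 2.9
- compound 2 `CC(C)n1cc(-c2ccnc3[nH]c(C4CCN(CC(=O)N5CCCCC5)CC4)cc23)ccc1=O` gives 2.8

In this assay compound 2 stands within the scatter of compound 1, so these two values set no order between them. The next compound, compound 3 `CC(C)n1cc(-c2ccnc3[nH]c(C4CCN(CC(=O)N(C)C)CC4)cc23)ccc1=O`, remains unmeasured. It departs from compound 2 in one place, with dimethylamino in place of piperidin-1-yl on a carbonyl carbon. Among the measured compounds shown here, compound 1 also carries the (dimethylcarbamoyl)methyl group, but its core substituent differs from that of compound 3, and no measured pair isolates this change. The expectation therefore rests on the structural change alone. The estimated step of a number 0.70 log units lower from compound 2 to compound 3 (beyond the scatter) is downward and is expected to lie beyond the scatter. Compound 3 is estimated at 2.1 within an expected range from 1.7 to 2.5 on this scale.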

Compound 3, distribution coefficient: 1.9
For compound 3 the middle estimate is 0.20 log units above the measured one, within the range that was stated.
By their numbers in this assay, from the lowest: compound 3; then compounds 2 and 1 (each within the scatter of the next).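

In this assay the exchange of piperidin-1-yl for dimethylamino on a carbonyl carbon gives a number 0.90 log units lower from compound 2 to compound 3 (beyond the scatter) and so puts the first measured size on this change, with the rest of the molecule held constant. With the (dimethylcarbamoyl)methyl group shared, the other place also counts: a group of 10 heavy atoms with a six-membered aromatic ring holding one hetero atom, in place of a group of 9 heavy atoms with an all-carbon aromatic ring on an aromatic carbon, gives a number 1.00 log units lower from compound 1 to compound 3 (beyond the scatter) and shows that this group moves the reading as well. No measurement shown accounts for either step.

From the compounds shown here alone, each change is read only once, so whether the amide step would hold with the aromatic group of compound 1 stays open. Where pyrrolidin-1-yl or morpholin-4-yl on the same carbonyl carbon would fall also stays open.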